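From 4-fluorophenyl to 3-iodophenyl on a shared core

The source may hold more compounds than are shown below. What is called first, only, known or untested is meant among the compounds shown, and "the series" means these compounds.

Of the compounds shown here, three have been measured in a functional assay on PANC-1 cells (Homo sapiens) for antiproliferative activity, read by sulforhodamine B assay, with a stated time of 48 h; on this read-out lower numbers stand for stronger inhibition of growth and higher numbers for weaker inhibition of growth. Compound 1 `ClC1=C(c2nnc(-c3ccccc3)o2)CCCc2ccccc21` gives 675 nM, compound 2 `Cc1cc2c(cc1C)C(Cl)=C(c1nnc(-c3ccccc3)o1)CCC2` gives 4120 nM, and compound 3 `Cc1cc2c(cc1C)C(Cl)=C(c1nnc(-c3ccc(F)cc3)o1)CCC2` gives 520 nM. Compound 3 and compound 1 lie within the scatter of each other, and compound 3 stands well below compound 2.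

The next structure is compound 4 `Cc1cc2c(cc1C)C(Cl)=C(c1nnc(-c3cccc(I)c3)o1)CCC2`, and the change from compound 3 is 3-iodophenyl in place of 4-fluorophenyl on an aromatic carbon. In words, 3-iodophenyl takes the place of 4-fluorophenyl on an aromatic carbon of a five-membered aromatic ring with 2 nitrogen and 1 oxygen.

Going by the values given here, only one measured step bears on this change. Putting fluoro in place of hydrogen on an aromatic carbon gave a 7.9-fold lower number from compound 2 to compound 3 (0.90 log units; beyond the scatter). Among the compounds with values here, that step shows that a single replacement on this aromatic ring can move the number clearly, but no measured compound carries iodine, so the guide is indirect. The value of compound 2, 4120 nM, suggests how far the number might climb if the gain seen with compound 3 were lost.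

In this assay a slightly higher number is expected, most likely not beyond the scatter. The expected move is a 1.5-fold higher number from compound 3 to compound 4 (0.19 log units; within the scatter). For compound 4 the estimated value is 800 nM, with an expected range from 250 nM to 3000 nM.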

Compound 4, concentration for 50% growth inhibition: 4120 nM
Beside the measured number, compound 4's estimate is 5.2-fold (0.71 log units) below it, outside the stated range (above it).
By their numbers in this assay, from the lowest: compounds 3 and 1 (each within the scatter of the next); then compounds 2 and 4 (each within the scatter of the next).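

In this assay the swap of 4-fluorophenyl for 3-iodophenyl gives a 7.9-fold higher number from compound 3 to compound 4 (0.90 log units; beyond the scatter) and so shows that the gain seen with 4-fluorophenyl on this shared core does not extend to every halogen-bearing phenyl group at this place on the five-membered aromatic ring. Setting iodo in place of hydrogen on the phenyl ring gives no change at the digits printed from compound 2 to compound 4 (within the scatter) and so leaves 3-iodophenyl level with the unsubstituted phenyl of compound 2, while 4-fluorophenyl is the only one of the three groups on this core that stands apart from the others. Nothing measured here explains why these two halogen-bearing groups part so clearly in this assay.

The step from 4-fluorophenyl to 3-iodophenyl changes both the halogen and its place on the phenyl ring, and the compounds shown cannot tell which of the two changes accounts for the result. Also open, as far as these compounds go, is how the number would respond on this core to a phenyl ring carrying a different kind of group, such as an amine or a carboxylic acid.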